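The source may report more compounds than this note shows. Statements on the series, on what has been measured and on what is new or still open speak of the compounds shown alone.

Compound 3, with the structure `NC(=S)N/N=C1/C(=O)N(CN2CCN(c3ccnc4cc(Cl)ccc34)CC2)c2cccc(Cl)c21`, has the lowest number of the three compounds measured in an ADME assay on 184B5 cells (Homo sapiens) for cytotoxicity, read by sulforhodamine B assay, with a stated time of 48 h; on this read-out higher numbers stand for weaker inhibition of growth and lower numbers for stronger inhibition of growth. In that assay compound 3 gives 20700 nM. Compound 2, whose structure is `O=C1C(=O)N(CN2CCN(c3ccnc4cc(C(F)(F)F)ccc34)CC2)c2cc(Br)ccc21`, gives in this assay a value of 21800 nM, which lies within the scatter of the number for compound 3, so the two cannot be placed in any order. Compound 1, with the structure `O=C1C(=O)N(CN2CCN(c3ccnc4cc(Cl)ccc34)CC2)c2cccc(Br)c21`, gives in this assay a value of 49000 nM, and its gap to compound 3 is beyond the scatter. Compound 1 and compound 2 differ from compound 3 in more than one place, so no single change can be read from them.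

The step from compound 3 leads to compound 4, whose structure is `NC(=S)N/N=C1/C(=O)N(CN2CCN(c3ccnc4cc(Cl)ccc34)CC2)c2ccccc21`. The change is hydrogen in place of chloro on an aromatic carbon. Among the compounds with values here, no measured pair in this set shows the effect of such a change on its own. It is expected that the step will be small, a modest rise in the number if anything, and may well stay within the scatter, so that compound 4 is expected to give 27000 nM in this assay, with a range from 9000 nM to 70000 nM. The estimated step of a 1.3-fold higher number from compound 3 to compound 4 (0.12 log units; within the scatter) is therefore expected to be slight.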

Compound 4, concentration for 50% growth inhibition: 28800 nM
Compound 4: middle estimate off by 1.1-fold (0.03 log units), on the low side; the range from low to high includes it.
By their numbers in this assay, from the lowest: compounds 3, 2, 4 and 1 (each within the scatter of the next, the first and the last beyond it).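

Within the data shown here, the pair of compound 3 and compound 4 gives the first reading of a single change in this set: with hydrogen in place of chloro on an aromatic carbon, the step in this assay is a 1.4-fold higher number from compound 3 to compound 4 (0.14 log units; within the scatter) so the two compounds cannot be placed in any order. At this position, ortho to a fused ring and meta to a fused ring, the presence of the chloro therefore makes no difference that can be told from the scatter, with the rest of compound 3 held fixed. Nothing on hand gives a reason for this result.

As far as these compounds go, this single pair speaks only for chloro and hydrogen at this one aromatic carbon, so what a methoxy group, an amine or a carboxylic acid would give there remains open. Also open, from the compounds shown here alone, is whether the same swap would read alike in compounds such as compound 1, which carry a ketone carbonyl where compound 3 and compound 4 carry their thiosemicarbazone side chain.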